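The source may report more compounds than this note shows. Statements on the series, on what has been measured and on what is new or still open speak of the compounds shown alone.

Working notes on the series. One core runs through compound 1 `CCn1c(/C=C2/C(=O)Nc3ccc(F)cc32)nc2ccccc21`, compound 2 `CCn1c(/C=C2/C(=O)Nc3ccccc32)nc2ccccc21`, compound 3 `CC(C)n1c(/C=C2/C(=O)Nc3ccccc32)nc2ccccc21` and the still unmeasured compound 4 `CCn1c(/C=C2/C(=O)Nc3ccc(C)cc32)nc2ccccc21`. In a functional assay on DU-145 cells (Homo sapiens) for cytotoxicity, read by MTT assay, with a stated time of 48 h (a lower number here means a stronger inhibitor, a higher number a weaker inhibitor), compound 1 gives 40600 nM and compound 3 gives 38100 nM. Compound 2 gives > 50000 nM, which is the limit of > 50000 nM in this assay, at which 1 of the 3 values shown sits, and thus a limit rather than a number. The step of an at least 1.2-fold higher number from compound 1 to compound 2 (0.09 log units; that floor lies within the scatter) stays within the scatter, as does an at least 1.3-fold lower number from compound 2 to compound 3 (0.11 log units; that floor lies within the scatter). Compound 4 differs from compound 2 by methyl in place of hydrogen on an aromatic carbon. Going by the values given here, the one measured step touching this position, an at least 1.2-fold higher number from compound 1 to compound 2 (0.09 log units; that floor lies within the scatter), was small, so in this assay no step beyond the scatter is expected. Compound 4 is therefore estimated at 45000 nM, with a range from 20000 nM to 100000 nM. The expected step of an at least 1.1-fold lower number from compound 2 to compound 4 (0.04 log units; that floor lies within the scatter) is taken to lie within the scatter.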

Compound 4, half-maximal inhibitory concentration: 39300 nM
Beside the measured number, compound 4's estimate is 1.1-fold (0.06 log units) above it; low and high end bracket the measured number.
By their numbers in this assay, from the lowest: compounds 3, 4 and 1 (each within the scatter of the next). At a limit, above all of these: compound 2.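

Methyl and fluoro can now be compared directly at this aromatic carbon in this assay, and the step is a 1.0-fold lower number from compound 1 to compound 4 (0.01 log units; within the scatter), so the two groups are not told apart here. Against hydrogen, methyl gives an at least 1.2-fold lower number from compound 2 to compound 4 (0.10 log units; that floor lies within the scatter), which is only a floor. Compound 2 stands at a limit and not at a number: the limit of > 50000 nM in this assay, at which 1 of the 4 values shown sits.

From the compounds shown here alone, the true size of the steps from hydrogen stays open, as does whether an amine, a carboxylic acid or a longer chain at this aromatic carbon would move the number beyond the scatter.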